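The compounds below may be only part of what the source reports. "The series", "measured", "known", "first", "only" and "open" are said of these compounds alone.

Compound 2 `CC1=CC[C@H](C(C)(C)NC(=S)N/N=C/c2ccc(O)cc2)CC1` is the point of departure. In a functional assay on U-251 cells (Homo sapiens) for inhibition, read by sulforhodamine B assay, with a stated time of 48 h (on this read-out lower numbers stand for stronger inhibition of growth and higher numbers for weaker inhibition of growth), compound 2 gives > 100000 nM, which is a limit of the assay rather than a number. Its closest measured relative is compound 1 `COc1ccc(/C=N/NC(=S)NC(C)(C)[C@H]2CC=C(C)CC2)cc1`, which carries a methoxy group where compound 2 carries a hydroxy group; in this assay compound 1 gives 11400 nM. Putting hydrogen in place of that methyl produced an at least 8.7-fold higher number from compound 1 to compound 2 (0.94 log units; beyond the scatter), and the step is open-ended because of the limit of > 100000 nM in this assay, at which 1 of the 2 values shown sits. The change toward compound 3 `CC1=CC[C@H](C(C)(C)NC(=S)N/N=C/c2ccc(F)cc2)CC1` is fluoro in place of hydroxy on an aromatic carbon. Among the compounds with values here, no measured step covers a fluoro group directly; the only guide is that a hydroxy group at this position pushed the growth-inhibiting concentration beyond what the assay reports, while the methoxy group of compound 1 kept it measurable. Since fluoro, like methoxy, is not hydroxy, compound 3 is expected to return to the measurable range, giving an estimated at least 3.3-fold lower number from compound 2 to compound 3 (0.52 log units; beyond the scatter). Compound 3 is therefore expected to show about 30000 nM, with a likely range from 8000 nM to 100000 nM.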

Compound 3, concentration for 50% growth inhibition: > 100000 nM
Compound 3 ended at the assay's limit (the forecaster's own chance of this, stated with the estimate: 35%); middle value at least 3.3-fold (0.52 log units) from the limit.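

In this assay, fluoro in place of methoxy on this aromatic carbon gives an at least 8.7-fold higher number from compound 1 to compound 3 (0.94 log units; beyond the scatter). The loss seen earlier with the hydroxy group is therefore not particular to that group: fluoro, with 0 hydrogen-bond donors and 0 hydrogen-bond acceptors, also fails to give a measurable value, so having a hydrogen-bond donor at this place cannot be what separates the compounds shown. Of the three groups tried on this carbon, para to a large group, only the methoxy group of compound 1 gives a value that can be read as a number, while the step between the hydroxy and fluoro compounds cannot be read and the two cannot be ranked against each other: the limit of > 100000 nM in this assay, at which 2 of the 3 values shown sit.

On these data alone, how far beyond that limit the true values lie remains unknown, so the size of the drop from methoxy is known only as a minimum. Also open, as far as these compounds go, is what an ethoxy group, a methyl group or a dimethylamino group would do on this carbon, which would show whether a measurable value needs the oxygen with its methyl or only a group of similar size.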